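Swapping a Hydroxybenzyl Group for a Dihydroxyphenyl Group

The compounds below may be only part of what the source reports. "The series", "measured", "known", "first", "only" and "open" are said of these compounds alone.

Measured in an ADME assay on HEK-293T cells (Homo sapiens) for cytotoxicity, read by CCK-8 assay, with a stated time of 48 h; a lower number here means a stronger inhibitor, a higher number a weaker inhibitor:
- Compound 1 `O=S(=O)(NCCNC(=S)Nc1cccc(Cl)c1)c1ccc(-c2ccccc2OCc2cccc(O)c2)s1`: 17400 nM
- Compound 2 `O=S(=O)(NCCNC(=S)Nc1cc(C(F)(F)F)cc(C(F)(F)F)c1)c1ccc(-c2ccccc2OCc2cccc(O)c2)s1`: > 20000 nM

Compound 2 gives > 20000 nM, which is a limit of the assay and not a number. Its true value is therefore unknown.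

Compound 3 `O=S(=O)(NCCNC(=S)Nc1cc(C(F)(F)F)cc(C(F)(F)F)c1)c1ccc(-c2ccccc2Oc2ccc(O)c(O)c2)s1` differs from compound 2 in one place, on an oxygen on an aromatic ring: 3,4-dihydroxyphenyl in place of 3-hydroxybenzyl on an oxygen on an aromatic ring. In words, 3,4-dihydroxyphenyl takes the place of 3-hydroxybenzyl.

Within the data shown here, no measured step shows what this exchange does in this assay. Among the measured compounds shown here, the only exact number available is that compound 1 gives 17400 nM. On that basis, no change beyond the usual scatter is expected, and compound 3 may also end at the limit. The expected size of the move is an at least 1.2-fold lower number from compound 2 to compound 3 (0.09 log units; that floor lies within the scatter). For compound 3 the estimated value is 16000 nM, with an expected range from 6000 nM to 40000 nM.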

Compound 3, half-maximal inhibitory concentration: 12300 nM
For compound 3 the middle estimate is 1.3-fold (0.11 log units) above the measured one; the range from low to high includes it.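

In this assay, placing 3,4-dihydroxyphenyl on this oxygen in place of 3-hydroxybenzyl gives an at least 1.6-fold lower number from compound 2 to compound 3 (0.21 log units; that floor lies within the scatter). Compound 3 gives 12300 nM, so this change provides an exact value for a compound carrying the trifluoromethyl groups, a series whose only earlier member had given no exact value. The real size of the step remains unknown, because compound 2 stands at a limit and not at a number: the limit of > 20000 nM in this assay, at which 1 of the 3 values shown sits.

The exchange alters both the link between the oxygen and the ring and the number of hydroxy groups, so these compounds cannot separate the two changes. As far as these compounds go, a 3-hydroxyphenyl or a 3,4-dihydroxybenzyl group on the same oxygen could tell them apart, and it remains open whether 3,4-dihydroxyphenyl would act in the same way on the core of compound 1.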